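From 1,3-benzoxazol-2-yl to pyridin-3-yl in compound 2

The source may hold more compounds than are shown below. What is called first, only, known or untested is meant among the compounds shown, and "the series" means these compounds.

For the measured compounds named here, in a functional assay (blood) for inhibition, with Homo sapiens as the target (on this read-out lower numbers stand for stronger inhibition and higher numbers for weaker inhibition), compound 1 `CC(C)(C)Sc1c(CC(C)(C)C(=O)O)n(Cc2ccc(Cl)cc2)c2ccc(OCc3nc4ccccc4s3)cc12` gives 260 nM and compound 2 `CC(C)(C)Sc1c(CC(C)(C)C(=O)O)n(Cc2ccc(Cl)cc2)c2ccc(OCc3nc4ccccc4o3)cc12` gives 2500 nM as the higher of the two numbers so far. Going by the values given here, the one measured step is a 9.6-fold higher number from compound 1 to compound 2 (0.98 log units; beyond the scatter) on exchanging 1,3-benzothiazol-2-yl for 1,3-benzoxazol-2-yl, and it lies beyond the scatter. Compound 3 `CC(C)(C)Sc1c(CC(C)(C)C(=O)O)n(Cc2ccc(Cl)cc2)c2ccc(OCc3cccnc3)cc12` carries pyridin-3-yl in place of 1,3-benzoxazol-2-yl on a saturated chain carbon bound to an oxygen on an aromatic ring, with pyridin-3-yl in place of 1,3-benzoxazol-2-yl on a saturated chain carbon bound to an oxygen on an aromatic ring as the counted difference. Among the compounds with values here, no measured compound carries pyridin-3-yl, so that single step only gauges how far a change at this place can reach. A shift of similar size in either direction remains possible, but the expectation in this assay is a slightly lower number, not clearly beyond the scatter. The expected step is a 1.4-fold lower number from compound 2 to compound 3 (0.14 log units; within the scatter) as a working figure. For compound 3 the estimate is 1800 nM with an expected range from 450 nM to 7000 nM for now.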

Compound 3, half-maximal inhibitory concentration: > 3000 nM
Compound 3: only a limit was reported; the forecaster's own chance of this, stated with the estimate: 10%; at least 1.6-fold (0.22 log units) between middle value and limit.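

Compound 3 is reported in this assay only as a limit, > 3000 nM. Against the 1,3-benzothiazol-2-yl group the exchange gives an at least 11-fold higher number from compound 1 to compound 3 (1.06 log units; beyond the scatter), so this place on the saturated chain carbon now shows two separate replacements that both stay clearly weaker than compound 1, which holds the strongest inhibition of the three. Against the 1,3-benzoxazol-2-yl group the reading is an at least 1.2-fold higher number from compound 2 to compound 3 (0.07 log units; that floor lies within the scatter), so compound 2 and compound 3 cannot be put in order: the limit of > 3000 nM in this assay, at which 1 of the 3 values shown sits.

On these data alone, how far compound 3 really lies from compound 2 remains open, as does whether the ring sulfur of compound 1 or its fused ring pair matters more at this place. A quinolin-2-yl or a plain phenyl group on the same carbon would help separate those two readings.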